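A difluorophenyl variant of compound 3 and its expected half-life

The compounds below may be only part of what the source reports. "The series", "measured", "known", "first", "only" and "open" are said of these compounds alone.

In an in vivo ADME assay on the whole organism for metabolic stability, with Rattus norvegicus as the target, using cassette dosing (a higher number here means that the compound lasts longer, a lower number that the compound disappears faster), compound 3 `O=C(Nc1ccc(-n2ccccc2=O)cn1)[C@H]1C[C@](O)(c2ccccc2Cl)CN1C(=O)Nc1ccc(Cl)cc1` gives 2.9 h. Within the data shown here, that is the highest of the three numbers measured so far, though the gap to compound 1 lies within the scatter. Compound 1 `Cc1ccc([C@@]2(O)C[C@H](C(=O)Nc3ccc(-n4ccccc4=O)cn3)N(C(=O)Nc3ccc(Cl)cc3)C2)cc1` gives 1.8 h, and compound 2 `Cc1cccc([C@@]2(O)C[C@H](C(=O)Nc3ccc(-n4ccccc4=O)cn3)N(C(=O)Nc3ccc(Cl)cc3)C2)c1` gives 1.4 h. The steps between them were a 1.3-fold lower number from compound 1 to compound 2 (0.11 log units; within the scatter), a 1.6-fold higher number from compound 1 to compound 3 (0.21 log units; within the scatter) and a 2.1-fold higher number from compound 2 to compound 3 (0.32 log units; beyond the scatter). Compound 4 `O=C(Nc1ccc(-n2ccccc2=O)cn1)[C@H]1C[C@](O)(c2ccc(F)c(F)c2)CN1C(=O)Nc1ccc(Cl)cc1` has not yet been measured in this assay. It differs from compound 3 in one place: 3,4-difluorophenyl in place of 2-chlorophenyl on a saturated ring carbon. All three measured steps also exchange the aryl group on that same saturated ring carbon, and none of them moved the half-life by more than a modest amount, with two of the three within the scatter. The step from compound 3 to compound 4 is therefore expected to be small, with a slight fall more likely than a rise, a 1.3-fold lower number from compound 3 to compound 4 (0.12 log units; within the scatter). Compound 4 is estimated at 2.2 h, with a range from 1.2 h to 4 h.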

Compound 4, half-life: 2.1 h
Compound 4: the middle estimate sits 1.0-fold (0.02 log units) above what was measured, within the range that was stated.
By their numbers in this assay, from the lowest: compounds 2, 1, 4 and 3 (each within the scatter of the next, the first and the last beyond it).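

Among these compounds, with 3,4-difluorophenyl on the saturated ring carbon, this position now holds a fluorine-bearing aryl group for the first time, and in this assay the new group cannot be told apart from any of the three earlier ones (a 1.4-fold lower number from compound 3 to compound 4 (0.14 log units; within the scatter); a 1.5-fold higher number from compound 2 to compound 4 (0.18 log units; within the scatter); a 1.2-fold higher number from compound 1 to compound 4 (0.07 log units; within the scatter)). Among the compounds shown here, compound 4 therefore falls within the scatter of both compound 2 and compound 3, even though those two lie beyond the scatter of each other, so the only step beyond the scatter at this position remains the one between those two. Nothing available offers a reason for these half-lives. Every aryl group shown is a carbon-only six-membered aromatic ring bearing chlorine, methyl or fluorine. As far as these compounds go, whether a pyridine, or a phenyl carrying an amine or a carboxylic acid, would stay as close remains open.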